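From phenyl to phenethyl on a saturated chain

The source may hold more compounds than are shown below. What is called first, only, known or untested is meant among the compounds shown, and "the series" means these compounds.

compound 1 `COc1cc2c(cc1C(C)NC(=O)/C=C/c1ccccc1)C=CC(C)(C)O2` gives 107000 nM
compound 2 `COc1cc2c(cc1C(C)NC/C=C/c1ccccc1)C=CC(C)(C)O2` gives 14600 nM
compound 3 `COc1cc2c(cc1C(C)NCc1ccccc1)CCC(C)(C)O2` gives 15300 nM

All three compounds were read in an ADME assay on L6 cells (Rattus norvegicus) for cytotoxicity (on this read-out lower numbers stand for stronger inhibition and higher numbers for weaker inhibition), and this account follows compound 3. Compound 3 (15300 nM) stands within the scatter of compound 2 (14600 nM), while compound 1 (107000 nM) gives a higher number, beyond the scatter of compound 3.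

Compound 4 `COc1cc2c(cc1C(C)NCCCc1ccccc1)CCC(C)(C)O2` is still unmeasured. It differs from compound 3 by phenethyl in place of phenyl on a saturated chain carbon bound to an amine nitrogen with phenethyl in place of phenyl on a saturated chain carbon bound to an amine nitrogen. Among the compounds with values here, no measured pair shows this change alone. In this assay no step beyond the scatter is expected, with only a slight lean towards a lower number. The estimated step is a 1.4-fold lower number from compound 3 to compound 4 (0.14 log units; within the scatter) and stays within the scatter. Compound 4 is expected at 11000 nM (range 5000 nM to 25000 nM).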

Compound 4, half-maximal inhibitory concentration: 2630 nM
Compound 4: middle estimate off by 4.2-fold (0.62 log units), on the high side, and the stated range ends above it.
By their numbers in this assay, from the lowest: compound 4; then compounds 2 and 3 (each within the scatter of the next); then compound 1.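

Within the data shown here, with a 5.8-fold lower number from compound 3 to compound 4 (0.76 log units; beyond the scatter) in this assay, the earlier compounds' flat picture gives way: this saturated chain carbon bound to an amine nitrogen responds to what it carries, and phenethyl in place of phenyl moves the number beyond the scatter. The earlier compounds shown here differ in more than one place, so they could not isolate this change. No available evidence explains the step. The compounds shown leave open whether a longer chain would extend the step, and whether an amine or carboxylic acid in place of the phenyl end would preserve it.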